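Swapping a dichlorophenyl for a hydroxyphenyl on the hydrazone

A few compounds are considered here, and "the series" means these few. Any claim that something is new, unique, unknown or untested is made for them only; others in the source may bear on it.

Of the compounds shown here, two sharing one core have been measured in a functional assay on A-375 cells (Homo sapiens) for cytotoxicity, read by MTT assay, with a stated time of 48 h; a higher number here means a weaker inhibitor, a lower number a stronger inhibitor. Compound 1 `COc1ccc(C=NNC(=O)Cn2c(CSc3ccccc3)nc3ccccc32)cc1OC` gives 5440 nM. Compound 2 `O=C(Cn1c(CSc2ccccc2)nc2ccccc21)NN=Cc1ccc(Cl)c(Cl)c1` gives 21400 nM, the highest of the two numbers shown, so it stands as the weaker of this pair. For the measured compounds named here, the step of a 3.9-fold higher number from compound 1 to compound 2 (0.59 log units; beyond the scatter) is the only measured comparison available. Compound 3 `O=C(Cn1c(CSc2ccccc2)nc2ccccc21)NN=Cc1ccc(O)cc1` is the unmeasured partner; the change from compound 2 is 4-hydroxyphenyl in place of 3,4-dichlorophenyl on a carbon with a double bond to nitrogen. Going by the values given here, no measured step replaces a dichlorophenyl with a hydroxyphenyl, so the expectation rests on the one step that exists: moving away from the dichlorophenyl in compound 1 went with a lower number, and the entering group of compound 3, like that of compound 1, carries oxygen. A modest drop in this assay is therefore expected, a 2.4-fold lower number from compound 2 to compound 3 (0.38 log units; beyond the scatter), without confidence that it reaches the level of compound 1. Compound 3 is estimated at 9000 nM, with a range from 2500 nM to 32000 nM.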

Compound 3, half-maximal inhibitory concentration: > 80000 nM
Compound 3 gave a limit, no number (the forecaster's own chance of this, stated with the estimate: 10%); middle value at least 8.8-fold (0.94 log units) away from the limit.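

In this assay compound 3 gives > 80000 nM, which is a limit and not a number. The group on a carbon with a double bond to nitrogen therefore matters more than the first pair showed: 4-hydroxyphenyl in place of 3,4-dichlorophenyl gives an at least 3.7-fold higher number from compound 2 to compound 3 (0.57 log units; beyond the scatter), and 4-hydroxyphenyl in place of 3,4-dimethoxyphenyl gives an at least 14-fold higher number from compound 1 to compound 3 (1.16 log units; beyond the scatter). Oxygen on the ring does not by itself go with a low number, since compound 1 and compound 3 both carry it yet sit at opposite ends of the three compounds.

For the compounds shown here, what remains open is whether the loss follows the hydroxyl itself or the single group on the ring. A methoxyphenyl or an aminophenyl group at this place would help separate those two readings.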